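Benzyl ring substitution in the thromboxane synthase series

This account rests on a few compounds, and the source may have more. Where it says the series, first, only, none or still open, it means among the compounds named here.

Compound 2 `CC(C)(Cc1ccccc1)C1OCC(C/C=C\CCC(=O)O)C(c2cccnc2)O1` carries a benzyl on the saturated chain carbon and gives 12 nM in an assay for inhibition of Thromboxane-A synthase (Homo sapiens), using microsomes; a lower number here means a stronger inhibitor, a higher number a weaker inhibitor. Compound 1 `CC(C)(Oc1ccccc1[N+](=O)[O-])C1OCC(C/C=C\CCC(=O)O)C(c2cccnc2)O1` reaches only the assay limit there, < 10 nM. That value is a limit and not a number (the limit of < 10 nM in this assay, at which 1 of the 2 values shown sits). Among the measured compounds shown here, the one step linking the two, an at least 1.2-fold higher number from compound 1 to compound 2 (0.07 log units; that floor lies within the scatter), is therefore of unknown size beyond its floor. For the measured compounds named here, compound 2 thus holds the only number in this assay; the other value shown is a limit.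

Compound 3 `CC(C)(Cc1ccc(F)cc1C#N)C1OCC(C/C=C\CCC(=O)O)C(c2cccnc2)O1` differs from compound 2 by 2-cyano-4-fluorophenyl in place of phenyl on a saturated chain carbon, two bonds along the chain from a saturated ring carbon. Going by the values given here, only the step from compound 1 to compound 2 touches the same part of the molecule, and it exchanged the whole group rather than the ring's substitution; its floor lies within the scatter. Among the compounds with values here, no measured step speaks to a cyano or a fluoro on that ring. In this assay a step within the scatter, or a little either way, is therefore expected for compound 3, no change at the digits printed from compound 2 to compound 3 (within the scatter). Compound 3 is estimated at 12 nM, with a range from 4 nM to 35 nM.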

Compound 3, half-maximal inhibitory concentration: < 10 nM
Compound 3 ended at the assay's limit; the forecaster's own chance of this, stated with the estimate: 25%; middle value at least 1.2-fold (0.07 log units) away from the limit.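

In this assay compound 3 gives < 10 nM and that is a limit, not a number. Among the compounds shown here, the change of phenyl to 2-cyano-4-fluorophenyl gives an at least 1.2-fold lower number from compound 2 to compound 3 (0.07 log units; that floor lies within the scatter) and is the first measured change to the substitution of this ring, on a saturated chain carbon, two bonds along the chain from a saturated ring carbon; a nitrile and a fluorine together are tolerated there, with no loss of inhibition visible in the read-out. Going by these compounds, how far this step runs past its floor stays unknown, and the step between the two limits cannot be read at all, because the read-out ends at the same limit for both compounds: the limit of < 10 nM in this assay, at which 2 of the 3 values shown sit.

The compounds shown leave open whether the nitrile or the fluorine alone would give the same reading, and whether either would do so elsewhere on the ring. Also open, on these data alone, is how an amine or a carboxylic acid on this ring would read, and whether any ring substitution here would give a value above the limit and so a step of readable size.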